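The source may hold more compounds than are shown below. What is called first, only, known or untested is meant among the compounds shown, and "the series" means these compounds.

Measured compounds in an assay on isolated protein for inhibition of Indoleamine 2,3-dioxygenase 1 (Homo sapiens), read by spectrophotometry; on this read-out lower numbers stand for stronger inhibition and higher numbers for weaker inhibition:

Compound 1, `O/N=C(/Nc1ccc(F)c(Cl)c1)c1ccc2occc2c1`, gives 5200 nM.
Compound 2, `O/N=C(/Nc1ccc(F)c(Br)c1)c1ccc2occc2c1`, gives 1600 nM.
Compound 3, `O/N=C(/Nc1cccc(Cl)c1)c1ccc2oc(COCC3CC3)cc2c1`, gives 1500 nM.

Compound 1 and compound 2 share a core and differ in one place: bromo in place of chloro on an aromatic carbon. That change brought a 3.3-fold lower number from compound 1 to compound 2 (0.51 log units; beyond the scatter). Compound 3 carries a different core, and the difference between the core of compound 1 and the core of compound 3 is not broken down here; the values of compound 1 and compound 3 alone show that compound 3 gives the lower number, while the values of compound 2 and compound 3 lie within the scatter of each other.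

Compound 4, `O/N=C(/Nc1cccc(Br)c1)c1ccc2oc(COCC3CC3)cc2c1`, is not yet measured. It is related to compound 3 by the same kind of change that relates compound 1 to compound 2: bromo in place of chloro on an aromatic carbon. The surroundings are not the same in both cases, since in compound 1 and compound 2 the changed carbon is also ortho to a fluoro group, whereas in compound 3 and compound 4 it is only meta to a large group.

For compound 4 in this assay a step of about a 2.5-fold lower number from compound 3 to compound 4 (0.40 log units; beyond the scatter) from compound 3 is expected, which rests on the step seen once before, a 3.3-fold lower number from compound 1 to compound 2 (0.51 log units; beyond the scatter), tempered by the differing surroundings and by the scatter of single measurements. Compound 4 is therefore estimated at 600 nM, with a likely range from 250 nM to 1500 nM.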

Compound 4, half-maximal inhibitory concentration: 400 nM
Compound 4: the middle estimate sits 1.5-fold (0.18 log units) above what was measured, within the range that was stated.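

In this assay, bromo in place of chloro on an aromatic carbon brought a 3.8-fold lower number from compound 3 to compound 4 (0.57 log units; beyond the scatter), so the direction seen on the core of compound 1 also appears on the core of compound 3. Set side by side, the two steps agree in size, even though the ring carrying the change has a fluoro group in compound 1 and compound 2 but not in compound 3 and compound 4: the same change on two cores in this assay, a 3.3-fold lower number (0.51 log units; beyond the scatter) from compound 1 to compound 2 and a 3.8-fold lower number (0.57 log units; beyond the scatter) from compound 3 to compound 4, 1.2-fold (0.06 log units) apart, within the scatter of two such steps This shows that the change carried over between these two cores in this assay, but it rests on only two pairs with one value per compound, so it does not show that the step would hold on any further core, and it does not explain why bromo gives the lower number in either pair.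

The compounds shown leave open whether iodo, methyl or trifluoromethyl in the same place would continue the step seen with bromo. They also leave open how the chain on the core of compound 3 would compare with a shorter ether, an amine or a carboxylic acid at that point.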